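Replacing Ethyl With 4-Methoxyphenyl: An Expected Outcome

The compounds below may be only part of what the source reports. "The series", "measured", "known", "first", "only" and "open" are said of these compounds alone.

Compound 1 `CCOC(=O)c1cnc(CC)nc1NN1C(=O)C=C(C)C1=O`: 10000 nM
Compound 2 `CCOC(=O)c1cnc(-c2csc(C)n2)nc1NN1C(=O)C=C(C)C1=O`: 8000 nM

Of the compounds shown here, two sharing one core have been measured in a functional assay on Jurkat cells for inhibition of nuclear factor NF-kappa-B complex (Homo sapiens); on this read-out higher numbers stand for weaker inhibition and lower numbers for stronger inhibition. Compound 1 gives 10000 nM, and compound 2 gives 8000 nM. The two sit within the scatter of each other, the step being a 1.3-fold lower number from compound 1 to compound 2 (0.10 log units; within the scatter), so neither can be called the stronger inhibitor on these numbers.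

Compound 3 `CCOC(=O)c1cnc(-c2ccc(OC)cc2)nc1NN1C(=O)C=C(C)C1=O` has not yet been measured. It differs from compound 1 in one place: 4-methoxyphenyl in place of ethyl on an aromatic carbon. Among the compounds with values here, the one measured step that bears on this change is the one from compound 1 to compound 2, where an aromatic ring also took the place of ethyl at the same position, and that step, a 1.3-fold lower number from compound 1 to compound 2 (0.10 log units; within the scatter), stayed within the scatter. Within the data shown here, on that basis a similar outcome is expected for compound 3, with no step beyond the scatter in either direction, though a 4-methoxyphenyl group is not a 2-methyl-1,3-thiazol-4-yl group and the single precedent leaves the range wide. The expected step from compound 1 is a 1.4-fold lower number from compound 1 to compound 3 (0.15 log units; within the scatter). Compound 3 is therefore estimated at 7000 nM in this assay, with a range from 2500 nM to 20000 nM.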

Compound 3, half-maximal inhibitory concentration: 900 nM
Compound 3: middle estimate off by 7.8-fold (0.89 log units), on the high side; the measured number lies below the stated range.
By their numbers in this assay, from the lowest: compound 3; then compounds 2 and 1 (each within the scatter of the next).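

Within the data shown here, the position on the aromatic carbon between two ring nitrogen atoms is not indifferent to its substituent, although the only earlier step there had stayed within the scatter and gave no sign of this. In this assay, 4-methoxyphenyl in place of ethyl gives an 11-fold lower number from compound 1 to compound 3 (1.05 log units; beyond the scatter) and so shows that a change at this position alone can move the read-out well beyond the scatter. The same group in place of 2-methyl-1,3-thiazol-4-yl gives an 8.9-fold lower number from compound 2 to compound 3 (0.95 log units; beyond the scatter), so an aromatic ring in place of ethyl is not enough in itself: compound 2 carries one and stays within the scatter of compound 1, and among these three compounds the stronger inhibition belongs to the 4-methoxyphenyl group alone.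

The compounds shown leave open whether the six-membered carbon ring or its methoxy group carries the step, a question that a plain phenyl group, a 4-hydroxyphenyl group or a 4-aminophenyl group at the same position would bear on. No measurement at hand gives a reason for the difference between compound 2 and compound 3.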